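Series notes: methoxy added to the shared core

The source may hold more compounds than are shown below. What is called first, only, known or untested is meant among the compounds shown, and "the series" means these compounds.

Measured so far:
compound 1, `CN1CCN(S(=O)(=O)c2ccc(N3CCC=N3)cc2)c2ccccc21` — 13 nM
compound 2, `CN1CCN(S(=O)(=O)c2ccc(N3CCCC3=O)cc2)c2ccccc21` — 13 nM

Both values come from a functional assay on MDA-MB-231 cells (Homo sapiens) for antiproliferative activity, read by fluorescence and SYBR Green assay, with a stated time of 24 h; on this read-out lower numbers stand for stronger inhibition and higher numbers for weaker inhibition. Among the compounds with values here, compound 2 stands level with compound 1 at the digits given; the one measured step, no change at the digits printed from compound 1 to compound 2 (within the scatter), lies within the scatter, so nothing separates the two on this read-out.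

Compound 3, `COc1ccc2c(c1)N(C)CCN2S(=O)(=O)c1ccc(N2CCCC2=O)cc1`, is not yet measured. It differs from compound 2 by methoxy in place of hydrogen on an aromatic carbon. Within the data shown here, this change sits on the shared core, whereas the only measured step exchanged the group attached to the other aromatic ring. Among the measured compounds shown here, no measured step in this set touches the shared core, so the step from compound 1 to compound 2 bears on the present change only indirectly: it shows that one exchange elsewhere left this assay unmoved, and gives no direction for a change on the core.

For the measured compounds named here, with no directly relevant step in hand, the expected step of no change at the digits printed from compound 2 to compound 3 (within the scatter) is none beyond the scatter, and the range is kept wide to reflect the lack of evidence. Compound 3 is accordingly estimated at 13 nM in this assay, with a range from 5 nM to 40 nM.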

Compound 3, half-maximal inhibitory concentration in the MDA-MB-231 assay: 14 nM
For compound 3 the middle estimate is 1.1-fold (0.03 log units) below the measured one; low and high end bracket the measured number.
By their numbers in the MDA-MB-231 assay, from the lowest: compounds 1, 2 and 3 (each within the scatter of the next).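

Within the data shown here, in the MDA-MB-231 assay, a 1.1-fold higher number from compound 2 to compound 3 (0.03 log units; within the scatter), so this is the first measured step on the shared core, and methoxy in place of hydrogen on this aromatic carbon leaves compound 3 level with compound 2. In a physicochemical assay for lipophilicity, at pH 7 (on this read-out higher numbers stand for higher lipophilicity and lower numbers for lower lipophilicity), compound 2 gives 1.9 and compound 3 gives 3, a separation that the earlier antiproliferative figures could not show. At this position, then, methoxy separates the two compounds in lipophilicity while their antiproliferative numbers stay level: the measured distribution coefficient of compound 2, 1.9, and of compound 3, 3, a number 1.10 log units higher (beyond the scatter)

The compounds shown leave open whether a group of another kind on this aromatic carbon, such as an amine or a carboxylic acid, would stay level with compound 2 in the MDA-MB-231 assay, and how far it would shift the distribution coefficient. Among these compounds, they also leave open whether methoxy on a different carbon of this ring, or methoxy combined with the other ring substituent of compound 1, would give the same picture, since the single step here covers one position and one partner group only.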